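Nitro in Place of Methoxy on Two Related Cores

The compounds below may be only part of what the source reports. "The series", "measured", "known", "first", "only" and "open" are said of these compounds alone.

Compound 1 `COc1ccc(C(=O)Nc2nc3c(OC)cccc3s2)cc1` was tested in a functional assay on MDA-MB-231 cells (Homo sapiens) for antiproliferative activity, read by sulforhodamine B assay (on this read-out higher numbers stand for weaker inhibition of growth and lower numbers for stronger inhibition of growth), where compound 1 gives 1.25 ug/mL. Compound 2 `COc1ccc(C(=O)Nc2nc3cc(OC)ccc3s2)cc1` is built from the same atoms joined differently; the difference between the two cores is not broken down here. In this assay compound 2 reaches only the limit of the assay, > 10 ug/mL, which is not a number. Compound 3 `COc1cccc2sc(NC(=O)c3ccc([N+](=O)[O-])cc3)nc12` carries one change relative to compound 1: nitro in place of methoxy on an aromatic carbon. In this assay compound 3 also sits at the limit, giving > 10 ug/mL. That change made a step of an at least 8.0-fold higher number from compound 1 to compound 3 (0.90 log units; beyond the scatter); its exact size cannot be given because of the limit of > 10 ug/mL in this assay, at which 2 of the 3 values shown sit. Compound 4 `COc1ccc2sc(NC(=O)c3ccc([N+](=O)[O-])cc3)nc2c1` stands to compound 2 as compound 3 stands to compound 1, through the same change at the same place: nitro in place of methoxy on an aromatic carbon. Compound 2 already sits at the limit, with > 10 ug/mL. The same change made a step of an at least 8.0-fold higher number from compound 1 to compound 3 (0.90 log units; beyond the scatter). On that basis compound 4 is expected to stay at or beyond the limit, an expected step that the limit leaves unreadable from compound 2 to compound 4. The estimated value for compound 4 is 30 ug/mL, with a likely range from 10 ug/mL to 100 ug/mL.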

Compound 4, concentration for 50% growth inhibition: > 10 ug/mL
Compound 4: only a limit was reported; the forecaster's own chance of this, stated with the estimate: 85%; the middle value lies beyond the limit too.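

No new step can be read between compound 2 and compound 4, since both give a limit and not a number, for this reason: the limit of > 10 ug/mL in this assay, at which 3 of the 4 values shown sit. The compounds shown leave open whether nitro in place of methoxy changes growth inhibition on the core of compound 2 in this assay, and how far past the limit either compound lies.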